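The source may hold more compounds than are shown below. What is called first, only, known or untested is meant among the compounds shown, and "the series" means these compounds.

Of the compounds shown here, three sharing one core have been tested in a functional assay on Caco-2 cells (Homo sapiens) for cytotoxicity, read by MTT assay, with a stated time of 48 h; on this read-out lower numbers stand for stronger inhibition and higher numbers for weaker inhibition. Compound 1, `O=C(O[C@H]1C[C@H](n2cc(F)c(=O)[nH]c2=O)O[C@@H]1COP(=O)(O)Oc1ccccc1)c1ccccc1`, gives 1020 nM, the lowest number of the three. Compound 2, `CCCCCCCCCc1ccc(OP(=O)(O)OC[C@H]2O[C@@H](n3cc(F)c(=O)[nH]c3=O)C[C@@H]2OC(=O)c2ccccc2)cc1`, gives 20400 nM, and compound 3, `CCCCCCCCCC[n+]1cccc(OP(=O)([O-])OC[C@H]2O[C@@H](n3cc(F)c(=O)[nH]c3=O)C[C@@H]2OC(=O)c2ccccc2)c1`, gives 12900 nM. Among the measured compounds shown here, only one pair among them differs in a single place: a 20-fold higher number from compound 1 to compound 2 (1.30 log units; beyond the scatter), where a nonyl group alone went with a far higher number. Compound 3 is not connected to compound 1 by such a single step; its number simply stands well above that of compound 1.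

Compound 4, `C[N+]1(C)CCC(OP(=O)([O-])OC[C@H]2O[C@@H](n3cc(F)c(=O)[nH]c3=O)C[C@@H]2OC(=O)c2ccccc2)CC1`, has not yet been measured. It differs from compound 1 in this way: a group of 12 heavy atoms (7 carbon, 1 nitrogen, 3 oxygen, 1 phosphorus; one six-membered non-aromatic ring with 1 hetero atom) in place of a group of 10 heavy atoms (6 carbon, 3 oxygen, 1 phosphorus; one six-membered aromatic ring of carbon only), on an oxygen on a saturated carbon. For the measured compounds named here, no nonyl group enters here, so the one measured step does not bear on it directly. The nearest guidance comes from compound 3, whose change from compound 1 also brings in a nitrogen: in this assay compound 3 gives 12900 nM, while compound 1 gives 1020 nM. With no closer comparison available, a moderate rise in the number, well short of what the nonyl brought, seems the most reasonable expectation. Compound 4 is therefore expected to show a 2.9-fold higher number from compound 1 to compound 4 (0.47 log units; beyond the scatter). Compound 4 is estimated to give 3000 nM, with a likely range from 900 nM to 10000 nM.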

Compound 4, half-maximal inhibitory concentration: 15700 nM
Compound 4: the middle estimate sits 5.2-fold (0.72 log units) below what was measured, and the stated range ends below it.
By their numbers in this assay, from the lowest: compound 1; then compounds 3, 4 and 2 (each within the scatter of the next).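

The change at this position need not involve a nonyl group to go with a much higher number. In this assay, replacing the group of compound 1 that carries a six-membered aromatic ring of carbon only with one that carries a six-membered non-aromatic ring with 1 hetero atom gives a 15-fold higher number from compound 1 to compound 4 (1.19 log units; beyond the scatter), a large step of the same broad kind as a 20-fold higher number from compound 1 to compound 2 (1.30 log units; beyond the scatter), so both single changes shown here, one adding a long chain and the other swapping the whole group, move away from the lower number of compound 1. Nothing measured here explains why the number rises with either change.

The compounds shown leave open which part of the entering group goes with the rise, the loss of the aromatic ring or the arrival of the charged nitrogen, and a cyclohexyl group on the same oxygen would help separate the two. They also leave open whether a short chain such as methyl on the aromatic ring of compound 1 would move the number at all, or whether only a chain as long as nonyl does.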